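The compounds below may be only part of what the source reports. "The series", "measured", "known", "first", "only" and "open" are said of these compounds alone.

The measured compounds, with their numbers in a functional assay (spleen, spleen) for activation, with Mus musculus as the target; on this read-out higher numbers stand for an effect only at larger amounts of compound and lower numbers for an effect already at smaller amounts:
compound 1 `CCSc1nc(N)c2nc(O)n(Cc3ccccc3)c2n1` gives 0.1 uM
compound 2 `CCCCCOc1nc(N)c2nc(O)n(Cc3ccccc3)c2n1` gives 0.01 uM
compound 3 `Nc1nc(S)nc2c1nc(O)n2Cc1ccccc1` gives 10 uM

Compound 3 has the highest number of the three; compound 1 is nearest and compound 2 furthest, and both gaps lie beyond the scatter. Compound 4 `CCCNc1nc(N)c2nc(O)n(Cc3ccccc3)c2n1` has not yet been measured. It differs from compound 3 in one place: propylamino in place of sulfanyl on an aromatic carbon. Within the data shown here, two measured steps bear on this change, both ending at compound 3. The step of a 100-fold higher number from compound 1 to compound 3 (2.00 log units; beyond the scatter) is hydrogen in place of ethyl on a sulfur, and the step of a 1000-fold higher number from compound 2 to compound 3 (3.00 log units; beyond the scatter) is sulfanyl in place of pentyloxy on an aromatic carbon. In both, the compound carrying an alkyl chain gave the far lower number, and compound 3, which carries none, gave the high one. Propylamino brings a chain back, so a large downward step is expected, a 100-fold lower number from compound 3 to compound 4 (2.00 log units; beyond the scatter). Compound 4 is therefore estimated at 0.1 uM, with a range from 0.01 uM to 1 uM.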

Compound 4, minimum effective concentration: 0.1 uM
Compound 4: the middle estimate sits on the measured number at the digits printed; the measured number falls inside the stated range.
By their numbers in this assay, from the lowest: compound 2; then compounds 1 and 4 (each within the scatter of the next); then compound 3.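

In this assay, the position between two ring nitrogen atoms now accepts a chain joined through nitrogen as well as through sulfur or oxygen, and a 100-fold lower number from compound 3 to compound 4 (2.00 log units; beyond the scatter) shows that propylamino, like the earlier chains, stands far from sulfanyl. Measured against the other chains, the result splits: no change at the digits printed from compound 1 to compound 4 (within the scatter) puts propylamino level with ethylsulfanyl, whereas a 10-fold higher number from compound 2 to compound 4 (1.00 log units; beyond the scatter) leaves pentyloxy ahead of it, so a chain at this position does not by itself reach the lowest number seen. Nothing available offers an explanation for these steps.

Propylamino and pentyloxy differ in both the joining atom and the chain, so the compounds leave open which of the two carries the gap between them. A pentylamino or a propoxy group would separate the two, and a dimethylamino group would show whether the hydrogen on the joining nitrogen matters.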